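Shortening the Linker on a Nucleotide Iodoacetamide Probe

A few compounds are considered here, and "the series" means these few. Any claim that something is new, unique, unknown or untested is made for them only; others in the source may bear on it.

Three nucleotide triphosphates carrying an iodoacetamide group were examined in an assay on isolated protein for inhibition of hexokinase-2 (Rattus norvegicus), with a stated time of 6 h, tested at 10 mM; a lower number here means less inhibition, a higher number more inhibition at the concentration tested (going by the name of the read-out). Compound 1 `CN(CCCCN(C)C(=O)CCCCNc1ncnc2c1ncn2[C@@H]1O[C@H](COP(=O)(O)OP(=O)(O)OP(=O)(O)O)[C@@H](O)[C@H]1O)C(=O)CCCCNC(=O)CI` gives 0% in this assay. Compound 2 `Nc1ncnc2c1nc(NCCCCNC(=O)CI)n2[C@@H]1O[C@H](COP(=O)(O)OP(=O)(O)OP(=O)(O)O)[C@@H](O)[C@H]1O` gives 0%, and compound 3 `O=C(CI)NCCCC(=O)NCCCCCCNc1ncnc2c1ncn2[C@@H]1O[C@H](COP(=O)(O)OP(=O)(O)OP(=O)(O)O)[C@@H](O)[C@H]1O` gives 0%. Compound 2 thus stands level with compound 1 and compound 3 at the digits shown, all within the usual scatter, so no order among the three can be read. Compound 4 `Nc1ncnc2c1nc(NCCNC(=O)CI)n2[C@@H]1O[C@H](COP(=O)(O)OP(=O)(O)OP(=O)(O)O)[C@@H](O)[C@H]1O` has not yet been measured in this assay. It differs from compound 2 in one place: ((iodomethyl)carbonyl)amino in place of 2-(((iodomethyl)carbonyl)amino)ethyl on a saturated chain carbon, two bonds along the chain from a nitrogen on an aromatic ring. Among the compounds with values here, no step between measured compounds is known; the expected change is no change at the digits printed from compound 2 to compound 4 (within the scatter), nothing beyond the scatter. Compound 4 is estimated at 0%, in a range from 0% to 10%.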

Compound 4, a percentage reported as inhibition, at one concentration (the size of the read-out at that concentration, not a potency): 0%
For compound 4 middle estimate and measured number coincide at the digits printed; measured number inside the range.
By their numbers in this assay, from the lowest: compounds 1, 2, 3 and 4 (each within the scatter of the next).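

Shortening the chain at this position, with ((iodomethyl)carbonyl)amino in place of 2-(((iodomethyl)carbonyl)amino)ethyl, gives in this assay no change at the digits printed from compound 2 to compound 4 (within the scatter) on this one change. Within the data shown here, this is the first comparison that isolates chain length at this position, and this shortening leaves the read-out unmoved. No supporting data offer an explanation for this result. From the compounds shown here alone, whether a longer chain at this position would shift the read-out remains open. So does the effect of an amine or a carboxylic acid in place of the iodoacetamide end.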